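This account rests on a few compounds, and the source may have more. Where it says the series, first, only, none or still open, it means among the compounds named here.

Of the compounds shown here, three of a shared core have been measured in a functional assay on OVCAR-3 cells (Homo sapiens) for inhibition, read by sulforhodamine B assay, with a stated time of 48 h (a higher number here means that more compound is tolerated, a lower number that less compound is tolerated), and a fourth awaits measurement. Compound 1 `Nc1cc(N)c2nc(-c3ccccc3)c(NCc3ccc(Cl)c(Cl)c3)nc2c1` is the only one of the three that gives a number: in this assay compound 1 gives 31600 nM. Compound 2 `CCOC(=O)[C@H](CCC(=O)O)NC(=O)c1ccc(Sc2nc3cc(N)cc(N)c3nc2-c2ccccc2)cc1` reaches only a limit of this assay, and that limit for compound 2 is < 100000 nM. Compound 3 `CCOC(=O)[C@H](CCC(=O)O)NC(=O)c1ccc(Oc2nc3cc(N)cc(N)c3nc2-c2ccccc2)cc1` likewise stops at a limit of this assay, and for compound 3 it reads < 100000 nM. Among the values shown, compound 1 thus stands as the single measured number, while the other two sit at the limit of < 100000 nM in this assay, at which 2 of the 3 values shown sit.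

Compound 4 `COc1ccc(CNc2nc3cc(N)cc(N)c3nc2-c2ccccc2)cc1` is the compound not yet measured. It differs from compound 1 in one place: 4-methoxyphenyl in place of 3,4-dichlorophenyl on a saturated chain carbon bound to a nitrogen on an aromatic ring. Going by the values given here, no step between two measured compounds is available, so the size of this change can only be anticipated, not read from a measured pair. Since the core and the rest of the molecule stay the same, the expected step in this assay from compound 1 to compound 4 is a 1.3-fold higher number from compound 1 to compound 4 (0.10 log units; within the scatter), a change that may well lie within the usual scatter, if anything toward a higher number. On that basis compound 4 is estimated at 40000 nM, with a range from 15000 nM to 100000 nM.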

Compound 4, concentration lethal to 50% of the cells: 38900 nM
Estimate against measurement, compound 4: 1.0-fold (0.01 log units) above; low and high end bracket the measured number.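

Going by these compounds alone, the step between these two compounds is the first measured one on the shared core, and it concerns the group on a saturated chain carbon bound to a nitrogen on an aromatic ring: in this assay the change from 3,4-dichlorobenzyl to 4-methoxybenzyl gives a 1.2-fold higher number from compound 1 to compound 4 (0.09 log units; within the scatter). The two chlorine atoms leave and a methoxy group with a hydrogen-bond acceptor enters, while the six-membered aromatic ring and the heavy-atom count stay the same, yet the two numbers cannot be told apart. At this position, then, this exchange of ring substituents leaves the read-out where it was, although a single pair shows this for these two groups only and gives no reason for it.

Still open, as far as these compounds go, is whether a phenyl ring carrying an amine or a carboxylic acid, or a longer chain in place of the saturated chain carbon, would move the number beyond the usual scatter. Compound 2 and compound 3 differ from compound 1 in more than one place and each gives only a limit, not a number: the limit of < 100000 nM in this assay, at which 2 of the 4 values shown sit.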